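Adding a methoxy to compound 1: what to expect

A few compounds are considered here, and "the series" means these few. Any claim that something is new, unique, unknown or untested is made for them only; others in the source may bear on it.

Compound 1 `N#Cc1c(N)cccc1S(=O)(=O)c1ccccc1` is the starting point here. In a functional assay on MT4 cells (Homo sapiens) for cytotoxicity (a lower number here means a stronger inhibitor, a higher number a weaker inhibitor), compound 1 gives > 5000 nM, which is a limit and not a measured number. Compound 4 `COc1ccc(S(=O)(=O)c2cccc(N)c2C#N)cc1` differs from it by methoxy in place of hydrogen on an aromatic carbon, a methoxy in place of hydrogen on an aromatic carbon, para to a large group.

Two measured compounds also carry a methoxy in place of hydrogen on an aromatic carbon. Compound 2 `COc1ccccc1S(=O)(=O)c1cccc(N)c1C#N` reads 146000 nM. Compound 3 `COc1cccc(S(=O)(=O)c2cccc(N)c2C#N)c1` reads > 200000 nM, which is again a limit. The two measured steps are a step that the limit leaves unreadable from compound 1 to compound 2 and a step that the two limits leave unreadable from compound 1 to compound 3, so neither offers a size to carry over.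

Within the data shown here, the only real number among the methoxy compounds is that of compound 2 at 146000 nM, so compound 4 is expected to read in the same very weak region. The expected change is a step that the limit leaves unreadable from compound 1 to compound 4, towards a higher number, and its size stays uncertain. For compound 4 the estimated value is 150000 nM, with an expected range of 50000 nM to 400000 nM.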

Compound 4, half-maximal inhibitory concentration: > 200000 nM
Compound 4: only a limit was reported; the forecaster's own chance of this, stated with the estimate: 50%; middle value at least 1.3-fold (0.12 log units) away from the limit.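

Compound 1 and compound 4 both read as limits in this assay, not as numbers, so no size can be given for the step between them. The compounds shown leave open how far a methoxy shifts the value, and whether its position on the ring matters.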